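The compounds below may be only part of what the source reports. "The series", "measured", "known", "first", "only" and "open" are said of these compounds alone.

Compound 1 `CC(=O)Nc1cccc(Cn2cc(-c3ccc4cn[nH]c4c3)ccc2=O)c1` gives 43 nM in an assay for inhibition of MAP kinase-interacting serine/threonine-protein kinase 2 (Homo sapiens), read by luminescence and ADP-Glo, with a stated time of 2 h; a lower number here means a stronger inhibitor, a higher number a weaker inhibitor.
Compound 3 `O=c1ccc(-c2ccc3cn[nH]c3c2)cn1Cc1cccc(C(F)(F)F)c1` gives 32 nM in this assay.
Compound 2 `O=C(N1CCOCC1)n1cc(-c2ccc3cn[nH]c3c2)ccc1=O` reaches only a limit, > 2000 nM, in this assay.

Compound 3 stands alongside compound 1 in this assay, as a 1.3-fold lower number from compound 1 to compound 3 (0.13 log units; within the scatter) shows a step within the scatter. Compound 2 is known only as a limit, (the limit of > 2000 nM in this assay, at which 1 of the 3 values shown sits). Compound 4 `Nc1cccc(Cn2cc(-c3ccc4cn[nH]c4c3)ccc2=O)c1` is to be measured in this assay; it differs from compound 3 by amino in place of trifluoromethyl on an aromatic carbon. Going by the values given here, the only measured step that bears on this position, from acetamido to trifluoromethyl, is a 1.3-fold lower number from compound 1 to compound 3 (0.13 log units; within the scatter), and it changed nothing beyond the scatter. Compound 4 is therefore expected to stay near compound 3, with a step of a 1.9-fold higher number from compound 3 to compound 4 (0.27 log units; within the scatter). The estimate for compound 4 in this assay is 60 nM, with a range from 20 nM to 200 nM.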

Compound 4, half-maximal inhibitory concentration: 84 nM
Beside the measured number, compound 4's estimate is 1.4-fold (0.15 log units) below it; the measured number falls inside the stated range.
By their numbers in this assay, from the lowest: compounds 3, 1 and 4 (each within the scatter of the next, the first and the last beyond it). At a limit, above all of these: compound 2.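

Going by these compounds alone, at this position, amino is the first replacement to move the number beyond the scatter in this assay, with a 2.6-fold higher number from compound 3 to compound 4 (0.42 log units; beyond the scatter). Removing the acetyl alone stays inside the scatter, with a 2.0-fold higher number from compound 1 to compound 4 (0.29 log units; within the scatter), so the amino and acetamido compounds cannot be told apart. The group on the aromatic nitrogen weighs far more, with an at least 23-fold lower number from compound 2 to compound 4 (1.37 log units; beyond the scatter), a step that starts from a limit: the limit of > 2000 nM in this assay, at which 1 of the 4 values shown sits.

The compounds shown leave open how a carboxylic acid, a nitrile or a longer chain would fare on this aromatic carbon. They also leave open whether 3-substituted benzyl is needed on the aromatic nitrogen.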